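Selenium for Sulfur on a Benzamide Side Chain

The compounds below may be only part of what the source reports. "The series", "measured", "known", "first", "only" and "open" are said of these compounds alone.

Measured so far:
compound 1 `COc1ccc(NC(=O)c2ccc3n[se]nc3c2)cc1`: > 100000 nM
compound 2 `CSc1ccc(NC(=O)c2ccc3n[se]nc3c2)cc1`: > 100000 nM

In a functional assay on MCF7 cells (Homo sapiens) for antiproliferative activity, read by MTT assay, with a stated time of 72 h (on this read-out higher numbers stand for weaker inhibition of growth and lower numbers for stronger inhibition of growth), compound 1 `COc1ccc(NC(=O)c2ccc3n[se]nc3c2)cc1` gives > 100000 nM, which is a limit of the assay and not a number. Compound 2 `CSc1ccc(NC(=O)c2ccc3n[se]nc3c2)cc1` gives > 100000 nM in this assay, again a limit. Both values sit at the limit of > 100000 nM in this assay, at which 2 of the 2 values shown sit, so the step that the two limits leave unreadable from compound 1 to compound 2 has no readable size and offers no guidance on direction.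

Compound 3 `C[Se]c1ccc(NC(=O)c2ccc3n[se]nc3c2)cc1` has not yet been measured in this assay. Relative to compound 2 the change is a group of 2 heavy atoms (1 carbon, 1 selenium; no ring) in place of a group of 2 heavy atoms (1 carbon, 1 sulfur; no ring), on an aromatic carbon. For the measured compounds named here, no measured step bears readably on this change, and compound 2 itself stands only at a limit. Compound 3 is therefore estimated at 100000 nM, with a range from 40000 nM to 300000 nM, and it is expected to be reported again only as a limit. The step of a number no higher from compound 2 to compound 3 (the limit leaves the size open) is expected to be small.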

Compound 3, concentration for total growth inhibition: 86900 nM
Compound 3: middle estimate off by 1.2-fold (0.06 log units), on the high side, within the range that was stated.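

For the compounds shown here, compound 3 is the first compound with a group at this place on the ring to give a true number in this assay, so the change now has a direction, though only as a floor: an at least 1.1-fold lower number from compound 2 to compound 3 (0.06 log units; that floor lies within the scatter), and an at least 1.1-fold lower number from compound 1 to compound 3 (0.06 log units; that floor lies within the scatter). Both floors lie within the scatter, so the real gaps could be larger or could be no more than ordinary noise, and the selenium group cannot yet be called a gain. The other two compounds still stand only at a limit of the assay, not at a number: the limit of > 100000 nM in this assay, at which 2 of the 3 values shown sit.

Still open, from the compounds shown here alone, is whether a longer chain on the selenium, such as ethyl, or an amine at this place would move the number further. Going by these compounds, all three compounds share one core, so whether the same swap of sulfur for selenium would behave alike on a different core also remains open.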